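A bromophenyl swap at the end of the chain

The compounds below may be only part of what the source reports. "The series", "measured", "known", "first", "only" and "open" are said of these compounds alone.

In a functional assay on the whole organism (strain Kunming) with Mus musculus as the target, with a stated time of 0.5 h (a lower number here means that less compound is needed, a higher number that more compound is needed for the effect), compound 1 `COc1cc(OC)c(OC)cc1/C=C/COC(=O)/C=C/c1ccc(OC)c(OC)c1` gives 140 umol/kg, and compound 2 `COc1cc(OC)c(OC)cc1/C=C/COC(=O)/C=C/c1ccccc1C(F)(F)F` gives 203 umol/kg. Compound 2 therefore stands within the usual scatter of compound 1, and the two cannot be told apart on these numbers. Compound 3 `COc1cc(OC)c(OC)cc1/C=C/COC(=O)/C=C/c1cccc(Br)c1` keeps the rest of compound 2 and alters one group: 3-bromophenyl in place of 2-(trifluoromethyl)phenyl on a double-bonded chain carbon bound to a double-bonded chain carbon. The new group sits on a double-bonded chain carbon bound to a double-bonded chain carbon. Among the compounds with values here, only one measured step bears on this place: a 1.5-fold higher number from compound 1 to compound 2 (0.16 log units; within the scatter). Within the data shown here, that exchange of one aromatic group for another stayed small, but it is a single step, and no compound carrying bromine has been measured yet. No step beyond the scatter is therefore expected in this assay. The expected change is a 1.2-fold lower number from compound 2 to compound 3 (0.08 log units; within the scatter). For compound 3 the estimate is 170 umol/kg, with an expected range of 80 umol/kg to 360 umol/kg.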

Compound 3, dose for half-maximal effect: 175 umol/kg
The estimate for compound 3 lay 1.0-fold (0.01 log units) below the measured number, within the range that was stated.
By their numbers in this assay, from the lowest: compounds 1, 3 and 2 (each within the scatter of the next).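

In this assay, putting 3-bromophenyl in place of 2-(trifluoromethyl)phenyl gives a 1.2-fold lower number from compound 2 to compound 3 (0.06 log units; within the scatter), and putting it in place of 3,4-dimethoxyphenyl gives a 1.3-fold higher number from compound 1 to compound 3 (0.10 log units; within the scatter), so neither exchange can be told apart from repeat-measurement noise. Where one step between two aromatic groups stood before, three differently substituted phenyl groups on a double-bonded chain carbon bound to a double-bonded chain carbon now give values that cannot be separated, and this now includes a group carrying bromine. No measurement is available that would explain this result.

From the compounds shown here alone, all three groups are substituted phenyl rings, so it remains open how a plain phenyl or a pyridine ring would behave here. An amine, a carboxylic acid or a longer chain at this place is also an open question.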